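Chloro in place of trifluoromethyl on the shared core

The source may report more compounds than this note shows. Statements on the series, on what has been measured and on what is new or still open speak of the compounds shown alone.

In a functional assay on A549 cells (Homo sapiens) for inhibition, read by MTT assay, with a stated time of 72 h (a higher number here means a weaker inhibitor, a lower number a stronger inhibitor), compound 1 (`COc1cc(OC)c(C(=O)/C=C/c2ccc(O)cc2)c(OC)c1`) gives 49400 nM, compound 2 (`COc1cc(OC)c(C(=O)/C=C/c2ccc(O)c(O)c2)c(OC)c1`) gives 8200 nM and compound 3 (`COc1cc(OC)c(C(=O)/C=C/c2ccc(C(F)(F)F)cc2)c(OC)c1`) gives 14200 nM. Compound 3 stands within the scatter of compound 2, and both sit clear of compound 1, with modest steps: a 6.0-fold lower number from compound 1 to compound 2 (0.78 log units; beyond the scatter) and a 3.5-fold lower number from compound 1 to compound 3 (0.54 log units; beyond the scatter). Compound 4 (`COc1cc(OC)c(C(=O)/C=C/c2ccc(Cl)cc2)c(OC)c1`) carries chloro in place of trifluoromethyl on an aromatic carbon. Among the measured compounds shown here, no measured step involves chloro, so the two modest steps offer only indirect guidance, and both replace or add to the hydroxy of compound 1. The expected step, a 1.1-fold higher number from compound 3 to compound 4 (0.02 log units; within the scatter), stays within the scatter. The estimate for compound 4 is 15000 nM, with an expected range of 6000 nM to 35000 nM.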

Compound 4, half-maximal inhibitory concentration: 13300 nM
Compound 4: middle estimate off by 1.1-fold (0.05 log units), on the high side; measured number inside the range.
By their numbers in this assay, from the lowest: compounds 2, 4 and 3 (each within the scatter of the next); then compound 1.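

In this assay, chloro and trifluoromethyl on this aromatic carbon, para to a large group, are not told apart: a 1.1-fold lower number from compound 3 to compound 4 (0.03 log units; within the scatter), although one heavy atom replaces four. Chloro in place of the hydroxy of compound 1 gives a 3.7-fold lower number from compound 1 to compound 4 (0.57 log units; beyond the scatter), a second replacement that clears the scatter, while the 4-chlorophenyl change gives a 1.6-fold higher number from compound 2 to compound 4 (0.21 log units; within the scatter). No available measurement explains why these groups read alike.

Still open, going by these compounds, is whether fluoro, an amine or a carboxylic acid at this position would stay level with compound 4.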